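Compound 2 to compound 4: formyl to hydroxymethyl

The compounds below may be only part of what the source reports. "The series", "measured", "known", "first", "only" and "open" are said of these compounds alone.

Compound 2 (`O=Cc1cn(Cc2ccc(Cl)cc2)c2ccc(F)cc12`) gives > 31600 nM in an ADME assay on T29 cells (Homo sapiens) for cytotoxicity, read by sulforhodamine B assay, with a stated time of 3 days (on this read-out higher numbers stand for weaker inhibition and lower numbers for stronger inhibition), as a limit and not a number. Compound 1 (`O=Cc1cn(Cc2cccc(C(F)(F)F)c2)c2ccccc12`) gives > 31600 nM in this assay as a limit. Compound 3 (`O=Cc1cn(Cc2ccc(Cl)cc2)c2ccc(Cl)cc12`) gives > 31600 nM in this assay as a limit. Compound 4 (`OCc1cn(Cc2ccc(Cl)cc2)c2ccc(F)cc12`) carries hydroxymethyl in place of formyl on an aromatic carbon. Among the measured compounds shown here, the only measured step is a step that the two limits leave unreadable from compound 2 to compound 3 and it involves a different change, so it sets no size. The available evidence is the limit of > 31600 nM in this assay, at which 3 of the 3 values shown sit, and on that basis no step beyond the scatter is expected in this assay and another limit is the likeliest report. The estimated change is a number no higher from compound 2 to compound 4 (the limit leaves the size open) and no more. For compound 4 the expected value is 31600 nM with an estimated range of 12000 nM to 60000 nM in this series.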

Compound 4, half-maximal inhibitory concentration: 8120 nM
For compound 4 the middle estimate is 3.9-fold (0.59 log units) above the measured one; measured number outside the range, below it.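

In this assay, hydroxymethyl in place of formyl on an aromatic carbon of the five-membered aromatic ring gives an at least 3.8-fold lower number from compound 2 to compound 4 (0.59 log units; beyond the scatter). This position therefore responds to the change, and compound 4 alone among the compounds shown gives a number, whereas the step between the formyl compounds cannot be read. The size of the step remains a minimum, since the formyl side is only a limit: the limit of > 31600 nM in this assay, at which 3 of the 4 values shown sit.

Going by these compounds, what a carboxylic acid, an aminomethyl group or a longer chain such as hydroxyethyl would give at this position stays open. Also open, on these data alone, is whether hydroxymethyl in place of formyl on compound 3 would give a similar step.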